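The source may report more compounds than this note shows. Statements on the series, on what has been measured and on what is new or still open speak of the compounds shown alone.

Compound 1 `COc1ccc(Nc2nnc(Nc3nc(-c4ccc(Cl)cc4)cs3)s2)cc1`: 100 mg/kg
Compound 2 `Cc1ccc(Nc2nnc(Nc3nc(-c4ccc([N+](=O)[O-])cc4)cs3)s2)cc1`: 30 mg/kg

Of the compounds shown here, two that share one core have been tested in a functional assay on the whole organism (strain albino) with Mus musculus as the target, in the maximal electroshock model, with a stated time of 0.5 h; a higher number here means that more compound is needed for the effect, a lower number that less compound is needed. Among the two numbers, compound 2 stands at the lowest; compound 1 sits at a higher number, and the gap between them lies beyond the usual scatter of this kind of measurement, so compound 2 clearly needs less compound for the effect.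

The next compound, compound 3 `COc1ccc(Nc2nnc(Nc3nc(-c4ccc([N+](=O)[O-])cc4)cs3)s2)cc1`, has not yet been measured. It differs from compound 2 in one place: methoxy in place of methyl on an aromatic carbon. Within the data shown here, no pair of measured compounds differs in exactly this way, so there is no measured step to lean on, and the two known numbers say nothing about this change on their own.

The expected step, a 1.3-fold higher number from compound 2 to compound 3 (0.12 log units; within the scatter), is therefore small, with no clear direction and nothing beyond the scatter. For compound 3 the estimated result in this assay is 40 mg/kg, with a likely range from 15 mg/kg to 100 mg/kg.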

Compound 3, minimum effective dose: 30 mg/kg
Compound 3: the middle estimate sits 1.3-fold (0.12 log units) above what was measured; the measured number falls inside the stated range.
By their numbers in this assay, from the lowest: compounds 2 and 3 (each within the scatter of the next); then compound 1.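

In this assay, placing methoxy where methyl stood on the aromatic carbon para to a large group gives no change at the digits printed from compound 2 to compound 3 (within the scatter), so this position accepts either of these two small groups without a change that can be told from the scatter. Compound 3 also links the two earlier compounds, which differ in two places and so could not be compared directly: nitro in place of chloro on an aromatic carbon gives a 3.3-fold lower number from compound 1 to compound 3 (0.52 log units; beyond the scatter), which shows that, with the methoxy ring held the same, this swap on the other aromatic ring goes with a lower dose. Nothing available here explains either result.

The compounds shown leave open whether this position would stay as undemanding with a different kind of group, such as an amine, a carboxylic acid or a longer chain like butoxy. They also leave open whether the nitro-for-chloro step would be the same size with methyl on the other ring, and whether other groups, such as a nitrile, would match nitro there.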